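The source may report more compounds than this note shows. Statements on the series, on what has been measured and on what is new or still open speak of the compounds shown alone.

Compound 1 `CCC(CC)c1ccc2c(NCCCNCc3cc(F)ccc3OC)ccnc2c1` gives 23 10^-6 cm/s in an ADME assay for permeability, using PAMPA, with a stated time of 30 min, at pH 7.4 (on this read-out higher numbers stand for higher permeability and lower numbers for lower permeability), level with compound 2 `CCC(CC)c1ccc2c(NCCCNCc3ccco3)ccnc2c1` at 23 10^-6 cm/s. The step of no change at the digits printed from compound 1 to compound 2 (within the scatter) stays within the scatter. Compound 3 `COc1ccc(F)cc1CNCCCNc1ccnc2cc(-c3ccccc3)ccc12` differs from compound 1 as phenyl in place of pentan-3-yl on an aromatic carbon. Among the compounds with values here, no measured step touches this position, so only the flat behaviour of compound 1 and compound 2 under a change of a side group guides the expectation. With no donor or acceptor gained or lost, no step beyond the scatter is expected in this assay, and the expected step is a 1.2-fold lower number from compound 1 to compound 3 (0.06 log units; within the scatter). Compound 3 is therefore estimated at 20 10^-6 cm/s, within 10 10^-6 cm/s to 40 10^-6 cm/s.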

Compound 3, apparent permeability: 237 10^-6 cm/s
For compound 3 the middle estimate is 12-fold (1.07 log units) below the measured one; the whole stated range lies below it.
By their numbers in this assay, from the lowest: compounds 1 and 2 (each within the scatter of the next); then compound 3.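

The aromatic carbon bearing pentan-3-yl in compound 1 is a position to which this assay responds strongly: phenyl in place of pentan-3-yl gives a 10-fold higher number from compound 1 to compound 3 (1.01 log units; beyond the scatter), with no hydrogen-bond donor or acceptor gained or lost. The change on the saturated chain carbon showed nothing of this kind, giving no change at the digits printed from compound 1 to compound 2 (within the scatter). No measured evidence here bears on the reason for the large step.

From the compounds shown here alone, whether any aromatic ring at this carbon gives the same step remains open, and a cyclohexyl or pyridyl group there would test this. Also open, going by these compounds, is whether phenyl acts alike with the furan-2-yl side group of compound 2.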